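Working notes: aryl exchange from compound 3 to compound 4

The source may hold more compounds than are shown below. What is called first, only, known or untested is meant among the compounds shown, and "the series" means these compounds.

The series holds the shared core constant and varies the aryl group on a saturated chain carbon bound to an aromatic carbon and an oxygen on a saturated carbon. In a functional assay on Caco-2 cells (Homo sapiens) for inhibition, read by MTT assay, with a stated time of 48 h, tested at 10 uM (a lower number here means less inhibition of growth, a higher number more inhibition of growth at the concentration tested), compound 1 (`Cc1oc2c([C@H]3CCN(C)C[C@H]3O)c(O)cc(O)c2c(=O)c1C(O)c1ccc([N+](=O)[O-])cc1`) gives 5%, compound 2 (`Cc1oc2c([C@H]3CCN(C)C[C@H]3O)c(O)cc(O)c2c(=O)c1C(O)c1cccc(Cl)c1`) gives 4%, and compound 3 (`Cc1oc2c([C@H]3CCN(C)C[C@H]3O)c(O)cc(O)c2c(=O)c1C(O)c1ccc(F)c(Br)c1`) gives 6%. On these numbers compound 3 is not separated from the other two.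

The next structure is compound 4 (`Cc1oc2c([C@H]3CCN(C)C[C@H]3O)c(O)cc(O)c2c(=O)c1C(O)c1c(Cl)cccc1Cl`). The change is 2,6-dichlorophenyl in place of 3-bromo-4-fluorophenyl on a saturated chain carbon bound to an aromatic carbon and an oxygen on a saturated carbon, with 2,6-dichlorophenyl in place of 3-bromo-4-fluorophenyl at the same place.

All three measured steps exchange the aryl group at this place, so all three bear on the new one. They read a number 1 percentage points lower from compound 1 to compound 2 (within the scatter), a number 1 percentage points higher from compound 1 to compound 3 (within the scatter) and a number 2 percentage points higher from compound 2 to compound 3 (within the scatter). Within the data shown here, no measured compound carries the 2,6-dichlorophenyl group, so the support is indirect and the range is kept wide. On that basis, no step beyond the scatter is expected in this assay, in either direction.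

The expected step is a number 1 percentage points lower from compound 3 to compound 4 (within the scatter). For compound 4 the estimated value is 5%, with an expected range of 0% to 14%.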

Compound 4, percent growth inhibition at one concentration: 24%
Beside the measured number, compound 4's estimate is 19 percentage points below it; measured number outside the range, above it.
By their numbers in this assay, from the lowest: compounds 2, 1 and 3 (each within the scatter of the next); then compound 4.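

In this assay, the aryl group on a saturated chain carbon bound to an aromatic carbon and an oxygen on a saturated carbon now proves able to shift the read-out: a number 18 percentage points higher from compound 3 to compound 4 (beyond the scatter), a number 20 percentage points higher from compound 2 to compound 4 (beyond the scatter) and a number 19 percentage points higher from compound 1 to compound 4 (beyond the scatter), whereas the earlier exchanges among 4-nitrophenyl, 3-chlorophenyl and 3-bromo-4-fluorophenyl stayed within the scatter. The exchange from 3-bromo-4-fluorophenyl to 2,6-dichlorophenyl leaves the heavy-atom count, the single aromatic ring, the hydrogen-bond donor and acceptor counts and the net charge unchanged, so these counts do not separate compound 4 from compound 3. No measurement available here accounts for the difference in growth inhibition.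

Compound 4 is the only compound carrying 2,6-dichlorophenyl, so the compounds shown do not tell whether the step depends on the chlorines themselves or on their arrangement on the ring, and a phenyl group with two methyl groups in place of the two chlorines would test the first of these. The read-out also comes from a single concentration, which leaves the concentration dependence of the growth inhibition by compound 4 open.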